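A few compounds are considered here, and "the series" means these few. Any claim that something is new, unique, unknown or untested is made for them only; others in the source may bear on it.

Measured so far in an assay on CHO cells for displacement of a labelled ligand from melanin-concentrating hormone receptor 1 (Homo sapiens), read by scintillation counting, with a stated time of 1 h; on this read-out lower numbers stand for stronger inhibition and higher numbers for weaker inhibition:
compound 1 `CCc1nc2ccc(-n3ccc(OCc4ccc(F)cc4)cc3=O)cc2n1C` gives 48 nM
compound 2 `Cn1c(C2CC2)nc2ccc(-n3ccc(OCc4ccc(F)cc4)cc3=O)cc21` gives 40 nM
compound 3 `Cn1c(CC2CC2)nc2ccc(-n3ccc(OCc4ccc(F)cc4)cc3=O)cc21` gives 90 nM

Compound 2 gives the lowest of the three numbers in this assay. The nearest is a 1.2-fold lower number from compound 1 to compound 2 (0.08 log units; within the scatter); the step of a 2.3-fold higher number from compound 2 to compound 3 (0.35 log units; beyond the scatter) is larger and modest. Compound 4 `Cn1c(C2CC2)nc2ccc(-n3ccc(OCc4csc(Cl)c4)cc3=O)cc21` keeps the core of compound 2 and changes only the ether group: 5-chlorothiophen-3-yl in place of 4-fluorophenyl on a saturated chain carbon bound to an oxygen on an aromatic ring. Among the measured compounds shown here, none of the measured steps touches this part of the molecule. The steps of a 1.2-fold lower number from compound 1 to compound 2 (0.08 log units; within the scatter), a 1.9-fold higher number from compound 1 to compound 3 (0.27 log units; within the scatter) and a 2.3-fold higher number from compound 2 to compound 3 (0.35 log units; beyond the scatter) all concern the group on the aromatic carbon of the core and stayed small, the largest being modest, so the series gives no direct handle on a change at the ether. With nothing shown to push the number either way, the expected step of a 1.3-fold higher number from compound 2 to compound 4 (0.10 log units; within the scatter) is none beyond the scatter, with a widened range for an untested swap. Compound 4 is estimated at 50 nM in this assay, within 18 nM to 160 nM.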

Compound 4, half-maximal inhibitory concentration: 14 nM
Beside the measured number, compound 4's estimate is 3.6-fold (0.55 log units) above it; the whole stated range lies above it.
By their numbers in this assay, from the lowest: compound 4; then compounds 2, 1 and 3 (each within the scatter of the next, the first and the last beyond it).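

In this assay, among the compounds shown here, the ether group proves to be a position that responds: a 2.9-fold lower number from compound 2 to compound 4 (0.46 log units; beyond the scatter), a modest step, and the only single change so far that lowers the number beyond the scatter. The aryl group on the saturated chain carbon bound to an oxygen on an aromatic ring therefore need not be 4-fluorophenyl, and a five-membered aromatic ring with 1 hetero atom is accepted there with the shared core unchanged. No data shown here account for the size or direction of this step.

The swap changes the ring, the hetero atom and the halogen together, so their separate contributions remain unresolved; a 4-chlorophenyl or an unsubstituted thiophen-3-yl group at this position would separate them. Going by these compounds, it also remains open whether the 5-chlorothiophen-3-yl group gives a similar step with the ethyl or cyclopropylmethyl group of compound 1 or compound 3.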